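Shortening the Acid Chain on a Shared Core

A few compounds are considered here, and "the series" means these few. Any claim that something is new, unique, unknown or untested is made for them only; others in the source may bear on it.

Of the compounds shown here, three built on one shared core have so far been measured in an assay on isolated protein for displacement of a labelled ligand from thyroid hormone receptor alpha (Homo sapiens), with a stated time of 3 h; a lower number here means a stronger inhibitor, a higher number a weaker inhibitor. Compound 1 `Cc1cc2cc(NC(=O)C(=O)O)ccc2n1Cc1ccc(O)c(C(C)C)c1` gives 230 nM in this assay, and compound 2 `Cc1cc2c(NC(=O)C(=O)O)cccc2n1Cc1ccc(O)c(C(C)C)c1` gives 230 nM, so the two values lie within the scatter of each other. Compound 3 `Cc1c(CCCCC(=O)O)c2ccccc2n1Cc1ccc(O)c(C(C)C)c1` carries instead a 4-carboxybutyl chain on the core. In this assay compound 3 returns only > 10000 nM, which is a limit of the assay and not a number, as noted for (the limit of > 10000 nM in this assay, at which 1 of the 3 values shown sits). Among the compounds with values here, no step between measured compounds that differ in a single place is available, so compound 3 stands alone at the limit with nothing to set it against directly.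

Compound 4 `Cc1c(CCC(=O)O)c2ccccc2n1Cc1ccc(O)c(C(C)C)c1` is the next compound to be measured. It differs from compound 3 by carboxy in place of 2-carboxyethyl on a saturated chain carbon, two bonds along the chain from an aromatic carbon. Since compound 3 sits only at > 10000 nM, the shortened chain is expected to bring at most a modest gain, with a fair chance that compound 4 also reaches only a limit. The step from compound 3 to compound 4 is estimated as an at least 1.2-fold lower number from compound 3 to compound 4 (0.09 log units; that floor lies within the scatter). Compound 4 is expected to give about 8000 nM in this assay, in a range from 1500 nM to 30000 nM.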

Compound 4, half-maximal inhibitory concentration: 1300 nM
For compound 4 the middle estimate is 6.2-fold (0.79 log units) above the measured one, outside the stated range (below it).
By their numbers in this assay, from the lowest: compounds 1 and 2 (each within the scatter of the next); then compound 4. At a limit, above all of these: compound 3.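

Shortening the acid chain from 4-carboxybutyl to 2-carboxyethyl, on a saturated chain carbon, two bonds along the chain from an aromatic carbon, gives the first step between compounds that differ in one place: an at least 7.6-fold lower number from compound 3 to compound 4 (0.88 log units; beyond the scatter). As far as these compounds go, this step is only a floor, and its true size stays unknown, because the value of compound 3 is a limit of the assay and not a number: the limit of > 10000 nM in this assay, at which 1 of the 4 values shown sits. Both compounds carry a carboxylic acid at the end of the chain, so within this pair the length of the chain alone separates a limit from a measured value in this assay, although compound 4 differs from compounds 1 and 2 in more than one place and cannot be set against them directly.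

The compounds shown leave open whether the number keeps falling with a still shorter carboxymethyl chain at this place, or whether the trend ends with the 2-carboxyethyl chain. They also leave open whether the carboxylic acid itself is needed on this chain, which an amide or a hydroxyl group at its end would test.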